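Benzylamino indazole series: hydroxycyclohexylamino for trifluoromethyl

The compounds below may be only part of what the source reports. "The series", "measured", "known", "first", "only" and "open" are said of these compounds alone.

Measured to date:
compound 1 `FC(F)(F)c1cccc(CNc2cc(Br)cc3[nH]ncc23)c1`, 16%
compound 2 `Nc1cc(CNc2cc(Br)cc3[nH]ncc23)ccc1O`, 32%
compound 3 `Brc1cc(NCc2cnc[nH]2)c2cn[nH]c2c1`, 16%

In an assay for inhibition of Indoleamine 2,3-dioxygenase 1 (Homo sapiens), with a stated time of 1 h, tested at 10 uM (a lower number here means less inhibition, a higher number more inhibition at the concentration tested (going by the name of the read-out)), compound 1 gives 16%, level at the digits shown with compound 3 and together the lowest of the three numbers; the gap to compound 3 lies within the scatter. Compound 2 stands furthest away with a number higher than compound 1 by an amount beyond the scatter.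

Compound 4 `OC1CCCC(Nc2cccc(CNc3cc(Br)cc4[nH]ncc34)c2)C1` is not yet measured in this assay. Relative to compound 1 it differs in one place: (3-hydroxycyclohexyl)amino in place of trifluoromethyl on an aromatic carbon. For the measured compounds named here, no step between measured compounds tells what this change does. Going by the values given here, the only pointer is compound 2, where the benzylamino ring carries amino and hydroxy groups and gives 32%.

A step from compound 1 to compound 4 of modest size in the upward direction is expected, a number 9 percentage points higher from compound 1 to compound 4 (within the scatter), though it could still fall within the scatter. Compound 4 is therefore estimated at 25%, in the range 5% to 50%.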

Compound 4, a percentage reported as inhibition, at one concentration (the size of the read-out at that concentration, not a potency): 52%
Compound 4: the middle estimate sits 27 percentage points below what was measured; the whole stated range lies below it.
By their numbers in this assay, from the lowest: compounds 1 and 3 (each within the scatter of the next); then compound 2; then compound 4.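

In this assay, for the compounds shown here, (3-hydroxycyclohexyl)amino in place of trifluoromethyl on this aromatic carbon, meta to a large group, gives a number 36 percentage points higher from compound 1 to compound 4 (beyond the scatter) and is the first step read at this position. The position therefore accepts a group with a six-membered non-aromatic ring and with hydrogen-bond donors and acceptors, none of which trifluoromethyl has, and inhibition at the tested concentration still rises. Nothing available explains the rise.

The ring, the linking nitrogen and the hydroxy group all enter in one step, so the compounds shown do not say which of them carries the change. A plain cyclohexylamino group, without the hydroxy, or an open 3-hydroxypropylamino chain, without the ring, would separate these parts.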